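From Methyl to Hydroxy in a Growth Inhibition Series

A few compounds are considered here, and "the series" means these few. Any claim that something is new, unique, unknown or untested is made for them only; others in the source may bear on it.

In a functional assay on SK-OV-3 cells (Homo sapiens) for inhibition, read by sulforhodamine B assay, with a stated time of 48 h (a higher number here means a weaker inhibitor of growth, a lower number a stronger inhibitor of growth), compound 1 (`CN(C)/C=C/C(=O)c1nn(-c2ccccc2)c(-c2ccccc2)c1C#N`) reads 23800 nM and compound 2 (`Cc1nnc(-c2nn(-c3ccccc3)c(-c3ccccc3)c2C#N)c2cn(-c3ccccc3)nc12`) reads 36800 nM so these two compounds stand within the usual scatter of each other. Compound 2 therefore offers a starting point level with compound 1, and neither can be ranked above the other. Compound 3 (`N#Cc1c(-c2nnc(O)c3nn(-c4ccccc4)cc23)nn(-c2ccccc2)c1-c1ccccc1`) keeps the core of compound 2 and differs from it in one place (hydroxy in place of methyl on an aromatic carbon): hydroxy in place of methyl on an aromatic carbon. Within the data shown here, no measured pair shows this change, and the two values give no direction for it. No shift beyond the scatter is therefore expected in this assay for this exchange. The estimated step is a 1.2-fold lower number from compound 2 to compound 3 (0.09 log units; within the scatter) and it stays within the scatter. Compound 3 is expected at 30000 nM with an estimated range from 12000 nM to 75000 nM as the likely span.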

Compound 3, concentration for 50% growth inhibition: 36800 nM
For compound 3 the middle estimate is 1.2-fold (0.09 log units) below the measured one; the measured number falls inside the stated range.
By their numbers in this assay, from the lowest: compounds 1, 2 and 3 (each within the scatter of the next).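

In this assay, among these compounds, the exchange of hydroxy for methyl on an aromatic carbon shows no change at the digits printed from compound 2 to compound 3 (within the scatter) and is the first single change on this core that can be read, as compounds 1 and 2 form no such pair. At this place, next to the ring nitrogen and para to a large group, hydroxy with its 1 hydrogen-bond donor and 1 hydrogen-bond acceptor therefore stands level with methyl, which has neither. Nothing at hand accounts for this result. 

As far as these compounds go, whether an amine, a methoxy group, a carboxylic acid or a longer chain at this place would read the same remains open. It also remains open whether any group here can move the number beyond the scatter, for the compounds shown contain no such step.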